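The source may report more compounds than this note shows. Statements on the series, on what has been measured and on what is new or still open speak of the compounds shown alone.

Measured in a functional assay on MIA PaCa-2 cells (Homo sapiens) for antiproliferative activity, read by MTT assay, with a stated time of 72 h; a higher number here means that more compound is needed for the effect, a lower number that less compound is needed: compound 1 `CNC(=O)c1cccc(Cn2nc(C)c(NC(=O)c3ccc(COc4cccc(OC)c4)cc3)c2C)c1` gives 6200 nM; compound 2 `CNC(=O)c1cccc(Cn2nc(C)c(NC(=O)c3ccc(COc4ccccc4Cl)cc3)c2C)c1` gives 6300 nM; compound 3 `CNC(=O)c1cccc(Cn2nc(C)c(NC(=O)c3ccc(COc4ccc(Cl)cc4)cc3)c2C)c1` gives 4200 nM.

Compound 3 holds the lowest of the three numbers, yet the steps to its neighbours, a 1.5-fold lower number from compound 1 to compound 3 (0.17 log units; within the scatter) and a 1.5-fold lower number from compound 2 to compound 3 (0.18 log units; within the scatter), both sit within the scatter, so no order can be read among them. Compound 4 `CNC(=O)c1cccc(Cn2nc(C)c(NC(=O)c3ccc(COc4ccccc4C(F)(F)F)cc3)c2C)c1` differs from compound 3 by 2-(trifluoromethyl)phenyl in place of 4-chlorophenyl on an oxygen on a saturated carbon. Among the measured compounds shown here, the steps that bear on the group carried by that oxygen are a 1.0-fold higher number from compound 1 to compound 2 (0.01 log units; within the scatter), a 1.5-fold lower number from compound 1 to compound 3 (0.17 log units; within the scatter) and a 1.5-fold lower number from compound 2 to compound 3 (0.18 log units; within the scatter), all within the scatter. A change of this kind is therefore expected to give no step beyond the scatter in this assay, a 1.2-fold higher number from compound 3 to compound 4 (0.08 log units; within the scatter). Compound 4 is thus estimated at 5000 nM, with a range from 2500 nM to 10000 nM.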

Compound 4, half-maximal effective concentration: 10000 nM
Beside the measured number, compound 4's estimate is 2.0-fold (0.30 log units) below it, and the stated range covers the measured number.
By their numbers in this assay, from the lowest: compounds 3, 1, 2 and 4 (each within the scatter of the next, the first and the last beyond it).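

With 2-(trifluoromethyl)phenyl on the oxygen, this position gives its first step beyond the scatter in this assay, a 2.4-fold higher number from compound 3 to compound 4 (0.38 log units; beyond the scatter) and modest in size. The other two steps, a 1.6-fold higher number from compound 2 to compound 4 (0.20 log units; within the scatter) and a 1.6-fold higher number from compound 1 to compound 4 (0.21 log units; within the scatter), stay within the scatter, so trifluoromethyl in place of chloro on an aromatic carbon shows no readable change, and compound 4 parts only from compound 3. Nothing measured here accounts for that step. On these data alone, it remains open whether an amine or a carboxylic acid on this phenyl ring would move the number further in either direction.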